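Fluoro for Chloro on the Benzylsulfanyl Arm

The source may report more compounds than this note shows. Statements on the series, on what has been measured and on what is new or still open speak of the compounds shown alone.

Of the compounds shown here, three of a shared core have been measured in a functional assay on the whole organism (artery, strain albino) with Rattus norvegicus as the target, with a stated time of 600 min, at a dose of 10 mg/kg by the oral route; a lower number here means less inhibition, a higher number more inhibition at the dose given (going by the name of the read-out). Compound 1 `CC1=C(C(=O)Nc2ccc(F)cc2)C(c2ccc([N+](=O)[O-])cc2)N=C(SCc2ccc(Cl)cc2)N1` gives 28.2%. Compound 2 `CC1=C(C(=O)Nc2ccc(F)cc2)C(c2ccc([N+](=O)[O-])cc2)N=C(SCc2ccc(F)cc2)N1` differs from compound 1 by fluoro in place of chloro on an aromatic carbon, and in this assay compound 2 gives 25.6%; the step of a number 2.6 percentage points lower from compound 1 to compound 2 (within the scatter). Compound 3 `CC1=C(C(=O)Nc2ccc(Br)cc2)C(c2ccc(Cl)cc2Cl)N=C(SCc2ccc(Cl)cc2)N1` carries a different set of substituents, and in this assay compound 3 gives 30.3%. The difference between the core of compound 3 and the core of compound 1 is not broken down here, so no single step can be read between those two compounds; their two values simply lie close to one another.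

Compound 4 `CC1=C(C(=O)Nc2ccc(Br)cc2)C(c2ccc(Cl)cc2Cl)N=C(SCc2ccc(F)cc2)N1` has not yet been measured. Within the data shown here, it differs from compound 3 by fluoro in place of chloro on an aromatic carbon, the same change as the one made from compound 1 to compound 2, at the same place. Because the earlier step of a number 2.6 percentage points lower from compound 1 to compound 2 (within the scatter) stayed within the usual scatter, the step from compound 3 to compound 4 is expected to be about a number 2.6 percentage points lower from compound 3 to compound 4 (within the scatter) in this assay. Compound 4 is therefore estimated to give 27.7% in this assay, most likely between 18% and 38%.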

Compound 4, a percentage reported as inhibition, in the whole organism at one dose (the size of the read-out at that dose, not a potency): 33.3%
Compound 4: middle estimate off by 5.6 percentage points, on the low side; measured number inside the range.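

Read on a second core, fluoro in place of chloro gives a number 3 percentage points higher from compound 3 to compound 4 (within the scatter) in this assay and stays on the same small scale as the step on the first core. Set side by side, the two steps do not separate the cores: the same change on two cores in this assay, a number 2.6 percentage points lower (within the scatter) from compound 1 to compound 2 and a number 3 percentage points higher (within the scatter) from compound 3 to compound 4, 5.6 percentage points apart, within the scatter of two such steps. Among these compounds, this shows that the change from (4-chlorobenzyl)sulfanyl to (4-fluorobenzyl)sulfanyl gives a step inside the scatter on both cores, but it does not show that the step is the same on both or that it would stay this small on a further core, as only two pairs are at hand and each is a reading at a single dose rather than a potency.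

The compounds shown leave open whether a group other than a halogen on this benzyl ring, such as an amine, a methoxy group or a carboxylic acid, would give a step beyond the scatter. They also leave open how these pairs would compare at another dose or time.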